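From a benzyl to an anilino group on the shared core

The compounds below may be only part of what the source reports. "The series", "measured", "known", "first", "only" and "open" are said of these compounds alone.

Compound 2 `Cc1cc(Cc2ccc(C#N)cc2)c(=O)n(CC(=O)Nc2ccc(Br)cc2)n1` is known only by a limit: in an assay on HL-60 cells for agonist activity at N-formyl peptide receptor 3 (Homo sapiens), read by calcium flux (a lower number here means that less compound is needed, a higher number that more compound is needed for the effect), compound 2 gives > 50000 nM, a limit of the assay rather than a number. Compound 1 `Cc1cc(Cc2cccc(Cl)c2)c(=O)n(CC(=O)Nc2ccc(Br)cc2)n1` also gives a limit in this assay, namely > 50000 nM. Both values sit at the limit of > 50000 nM in this assay, at which 2 of the 2 values shown sit, so the step that the two limits leave unreadable from compound 1 to compound 2 cannot be read. Compound 3 `COc1ccc(Nc2cc(C)nn(CC(=O)Nc3ccc(Br)cc3)c2=O)cc1` differs from compound 2 in that ((4-methoxyphenyl)amino in place of 4-cyanobenzyl on an aromatic carbon). On these data alone, no readable measured step bears on this change, so its direction in this assay stays open. Compound 3 is estimated at 20000 nM, expected between 2000 nM and 50000 nM. That estimate would mean an expected step of an at least 2.5-fold lower number from compound 2 to compound 3 (0.39 log units; beyond the scatter).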

Compound 3, half-maximal effective concentration: > 50000 nM
Compound 3: no number, only a limit; the forecaster's own chance of this, stated with the estimate: 55%; middle value at least 2.5-fold (0.39 log units) from the limit.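

Compound 3 also gives only a limit, so its steps from compound 1 and compound 2 cannot be read: the limit of > 50000 nM in this assay, at which 3 of the 3 values shown sit.

On these data alone, none of the three compounds has a number, so whether 3-chlorobenzyl, 4-cyanobenzyl and (4-methoxyphenyl)amino differ at all stays open.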